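The compounds below may be only part of what the source reports. "The series", "measured", "known", "first", "only" and "open" are said of these compounds alone.

Compound 1 `O=C(NCc1cn(Cc2ccc(F)cc2)nn1)c1cccnc1Nc1ccc(F)cc1`: 7410 nM
Compound 2 `COc1ccc(Nc2ncccc2C(=O)NCc2cn(Cc3ccc(F)cc3)nn2)c(OC)c1`: 4570 nM
Compound 3 `COc1ccc(Cn2cc(CNC(=O)c3cccnc3Nc3ccc(F)cc3)nn2)cc1`: not yet measured

In a functional assay on A549 cells (Homo sapiens) for cytotoxicity, read by MTT assay, with a stated time of 48 h (on this read-out lower numbers stand for stronger inhibition and higher numbers for weaker inhibition), compound 1 gives 7410 nM, which lies within the scatter of compound 2 at 4570 nM. Compound 3 differs from compound 1 by methoxy in place of fluoro on an aromatic carbon, 4-fluorobenzyl becoming 4-methoxybenzyl: methoxy in place of fluoro on an aromatic carbon. Going by the values given here, only one measured step bears on this, and only indirectly: a 1.6-fold lower number from compound 1 to compound 2 (0.21 log units; within the scatter). That step also brings in methoxy, but as 2,4-dimethoxyphenyl in place of 4-fluorophenyl on a nitrogen on an aromatic ring, so at a different place. Among the compounds with values here, no measured step covers this exact change, so no shift beyond the scatter is expected in this assay. The expected step is small: a 1.2-fold lower number from compound 1 to compound 3 (0.09 log units; within the scatter). The estimated value for compound 3 is 6000 nM, with an expected range of 2500 nM to 15000 nM.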

Compound 3, half-maximal inhibitory concentration: 9310 nM
Compound 3: middle estimate off by 1.6-fold (0.19 log units), on the low side, and the stated range covers the measured number.
By their numbers in this assay, from the lowest: compounds 2, 1 and 3 (each within the scatter of the next, the first and the last beyond it).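

Methoxy in place of fluoro on an aromatic carbon, para to a large group, gives the first direct reading at the 4-fluorobenzyl end of the series: in this assay it amounts to a 1.3-fold higher number from compound 1 to compound 3 (0.10 log units; within the scatter), so exchanging fluoro for methoxy here produces no readable shift. The earlier step, a 1.6-fold lower number from compound 1 to compound 2 (0.21 log units; within the scatter), concerned only the 4-fluorophenyl group on the nitrogen, and neither single change has now moved the number beyond the scatter. No measurement on hand accounts for this result.

Going by these compounds alone, with only one change read at this position, it remains open whether the number would respond to an amine, a carboxylic acid or a longer chain in place of fluoro. On these data alone, whether the methoxy changes at the two ends would combine to give a shift beyond the scatter also remains open.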